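Antiproliferative series: anilino substitution on the shared core

The source may hold more compounds than are shown below. What is called first, only, known or untested is meant among the compounds shown, and "the series" means these compounds.

Measured compounds:
compound 1 `O=C(C1=C(O)C(=O)N(CCCn2ccnc2)C1c1ccc(Br)cc1)c1ccccc1`: 73100 nM
compound 2 `O=C(C1=C(Nc2ccc(Br)cc2)C(=O)N(CCCn2ccnc2)C1c1ccc(Br)cc1)c1ccccc1`: 22200 nM

Compound 2 gives the lowest of the two numbers in a functional assay on A549 cells (Homo sapiens) for antiproliferative activity, read by MTT assay, with a stated time of 72 h; on this read-out lower numbers stand for stronger inhibition and higher numbers for weaker inhibition; its nearest neighbour is compound 1, and the step of a 3.3-fold lower number from compound 1 to compound 2 (0.52 log units; beyond the scatter) came from (4-bromophenyl)amino in place of hydroxy on a double-bonded ring carbon.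

Compound 3 `O=C(C1=C(Nc2ccc(OC(F)(F)F)cc2)C(=O)N(CCCn2ccnc2)C1c1ccc(Br)cc1)c1ccccc1` has not yet been measured. It differs from compound 2 by trifluoromethoxy in place of bromo on an aromatic carbon. Going by the values given here, no measured step touches the substituent on the anilino ring: the only step in hand, from compound 1 to compound 2, changes the group on the core itself, not its para substituent, so it does not bear on this change. With nothing to argue for a shift in either direction, a step within the scatter is expected, so that a 1.1-fold lower number from compound 2 to compound 3 (0.05 log units; within the scatter) is the estimated outcome. Compound 3 is therefore expected near 20000 nM, within a range of 7000 nM to 60000 nM.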

Compound 3, half-maximal inhibitory concentration: 20800 nM
The estimate for compound 3 lay 1.0-fold (0.02 log units) below the measured number; low and high end bracket the measured number.
By their numbers in this assay, from the lowest: compounds 3 and 2 (each within the scatter of the next); then compound 1.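

In this assay, the substituent on the anilino ring shows no effect that can be read for this pair: with a 1.1-fold lower number from compound 2 to compound 3 (0.03 log units; within the scatter), trifluoromethoxy, with 5 heavy atoms and a hydrogen-bond acceptor, cannot be told apart from bromo, with 1 heavy atom and none. The lower number relative to the hydroxy compound is also not confined to the (4-bromophenyl)amino group, since a 3.5-fold lower number from compound 1 to compound 3 (0.55 log units; beyond the scatter), so both anilino compounds now stand on the same side of compound 1. Nothing measured here gives a reason for either step.

Open, going by these compounds, is whether a different kind of group at this place, such as an amine or a carboxylic acid, would move the number beyond the scatter. Also open, on these data alone, is whether a substituent on this ring matters at all.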